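The compounds below may be only part of what the source reports. "The series", "measured", "known", "first", "only" and "open" are said of these compounds alone.

Three nucleosides sharing one core have been measured in a functional assay on CCRF-CEM cells (Homo sapiens), read by MTT assay, with a stated time of 72 h; on this read-out higher numbers stand for weaker inhibition and lower numbers for stronger inhibition. Compound 1 `COc1ncnc2c1c(-c1ccsc1)cn2[C@@H]1O[C@H](CO)[C@@H](O)[C@H]1O` gives 2570 nM, compound 3 `COc1ncnc2c1c(I)cn2[C@@H]1O[C@H](CO)[C@@H](O)[C@H]1O` gives 1150 nM, and compound 2 `O=c1[nH]cnc2c1c(-c1ccsc1)cn2[C@@H]1O[C@H](CO)[C@@H](O)[C@H]1O` gives 14500 nM, the highest of the three numbers, with the nearest neighbour compound 1 and the furthest compound 3. Going by the values given here, the one measured step, a 2.2-fold lower number from compound 1 to compound 3 (0.35 log units; beyond the scatter), is modest and beyond the scatter, but it exchanges the aromatic group for a halogen rather than for another ring.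

Compound 4 `O=c1[nH]cnc2c1c(-c1ccccc1)cn2[C@@H]1O[C@H](CO)[C@@H](O)[C@H]1O` differs from compound 2 by phenyl in place of thiophen-3-yl on an aromatic carbon. Among the compounds with values here, no measured step exchanges thiophen-3-yl for phenyl, so the only guide is that the group on this aromatic carbon moves the number by a modest amount when changed at all, as seen from compound 1 to compound 3.

Compound 4 is therefore expected to stay close to compound 2 in this assay, with an estimated value of 15000 nM, between 5000 nM and 45000 nM, a step of a 1.0-fold higher number from compound 2 to compound 4 (0.01 log units; within the scatter) that is expected to lie within the scatter.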

Compound 4, half-maximal inhibitory concentration: > 100000 nM
Compound 4: a limit, no number (the forecaster's own chance of this, stated with the estimate: 10%); middle value at least 6.6-fold (0.82 log units) away from the limit.
By their numbers in this assay, from the lowest: compound 3; then compound 1; then compound 2. At a limit, above all of these: compound 4.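

In this assay, replacing thiophen-3-yl with phenyl on this aromatic carbon gives an at least 6.8-fold higher number from compound 2 to compound 4 (0.83 log units; beyond the scatter), so this position does not treat the two aromatic rings alike. The earlier step at the same carbon, a 2.2-fold lower number from compound 1 to compound 3 (0.35 log units; beyond the scatter), was modest, whereas this one shows that a change here can move the number further, even when one aromatic ring replaces another. For compound 4 the value is a limit and not a number, so the step has a lower bound but no measured size: the limit of > 100000 nM in this assay, at which 1 of the 4 values shown sits.

The compounds shown leave open whether phenyl would have the same effect on the core of compound 1, which carries a methoxy group instead of the carbonyl, and how iodo would fare on the core of compound 2. They also leave open how this position would respond to a furan-2-yl ring, a methyl group or an amine.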